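Acetoxy in Place of Chloro: From Compound 2 to Compound 4

The source may hold more compounds than are shown below. What is called first, only, known or untested is meant among the compounds shown, and "the series" means these compounds.

Among the measured compounds shown here, compound 2 `O=C(/C(=C/C1CCCCC1)CCl)c1ccccc1` carries the highest of the three numbers measured so far: in a functional assay on T47D cells (Homo sapiens) for inhibition, read by sulforhodamine B assay, with a stated time of 48 h (on this read-out higher numbers stand for weaker inhibition of growth and lower numbers for stronger inhibition of growth), compound 2 gives 29000 nM. Closest to it is compound 3 `O=C(/C(=C/c1ccccc1)CCl)c1ccccc1`, which in this assay gives 18000 nM; the only single-point step available in the set is a 1.6-fold lower number from compound 2 to compound 3 (0.21 log units; within the scatter). Furthest from compound 2 is compound 1 `O=C(/C=C/c1ccc(Cl)cc1Cl)c1ccccc1`, which in this assay gives 14000 nM, a gap beyond the scatter.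

Compound 4 `CC(=O)OC/C(=C\C1CCCCC1)C(=O)c1ccccc1` differs from compound 2 in one place: acetoxy in place of chloro on a saturated chain carbon bound to a double-bonded chain carbon. For the measured compounds named here, no measured step concerns this exchange; the one step known, a 1.6-fold lower number from compound 2 to compound 3 (0.21 log units; within the scatter), changes a different position and a different pair of groups, so it offers no direct guide. For compound 4 the expectation is therefore no shift beyond the scatter, an estimated step of a 1.0-fold higher number from compound 2 to compound 4 (0.01 log units; within the scatter). Compound 4 is expected to give about 30000 nM in this assay, with a range from 12000 nM to 80000 nM.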

Compound 4, concentration for 50% growth inhibition: 22000 nM
The estimate for compound 4 lay 1.4-fold (0.13 log units) above the measured number; the measured number falls inside the stated range.
By their numbers in this assay, from the lowest: compounds 1, 3, 4 and 2 (each within the scatter of the next, the first and the last beyond it).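

In this assay, the chloro on a saturated chain carbon bound to a double-bonded chain carbon gives way to acetoxy, with 4 heavy atoms entering for 1 and 2 hydrogen-bond acceptors for 0, and this yields a 1.3-fold lower number from compound 2 to compound 4 (0.12 log units; within the scatter). Among the compounds shown here, this is the first reading at this place, and the two groups compared here, on the cyclohexyl compounds, cannot be told apart in this assay, so the chloro is not required for the growth inhibition seen with compound 2. Nothing at hand bears on the reason for this result.

From the compounds shown here alone, it remains open whether the same exchange reads alike on compound 3, which carries phenyl in place of cyclohexyl. Going by these compounds, it also remains open whether an amine, a free hydroxyl or a longer ester at this carbon would move the number beyond the scatter.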